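Hydroxy added to the methoxyphenyl of compound 2

A few compounds are considered here, and "the series" means these few. Any claim that something is new, unique, unknown or untested is made for them only; others in the source may bear on it.

Going by the values given here, compound 2 `COc1ccc(-c2cn(-c3ccc(OC(F)(F)F)cc3)nn2)cc1` holds the only plain number: in a functional assay on MDA-MB-231 cells (Homo sapiens) for cytotoxicity, read by MTT assay (a lower number here means a stronger inhibitor, a higher number a weaker inhibitor), compound 2 gives 1000 nM. Compound 1 `Oc1cc(O)cc(-c2cn(-c3ccc(OC(F)(F)F)cc3)nn2)c1` sits at a limit of the assay, not a number, and in this assay compound 1 gives > 10000 nM. Compound 3 `COc1ccc(-n2cc(-c3ccc(O)c(OC)c3)nn2)c(OC)c1` has no result in this assay ("not determined" (no result reported)).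

The change to compound 4 `COc1ccc(-c2cn(-c3ccc(OC(F)(F)F)cc3)nn2)cc1O` is hydroxy in place of hydrogen on an aromatic carbon.

Among the compounds with values here, one measured step bears on it. The exchange of the 3,5-dihydroxyphenyl for the 4-methoxyphenyl gave an at least 10-fold lower number from compound 1 to compound 2 (1.00 log units; beyond the scatter), but that step starts from a limit (the limit of > 10000 nM in this assay, at which 1 of the 3 values shown sits), so its true size is only bounded from below. Compound 4 puts one hydroxy back onto the aryl that compound 2 carries, a partial return toward the substitution of compound 1. A higher number than compound 2 is therefore expected for compound 4, modest in size, with a real chance the assay again reports only a limit; the expected step is a 2.5-fold higher number from compound 2 to compound 4 (0.40 log units; beyond the scatter).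

For compound 4 the estimate in this assay is 2500 nM, within 800 nM to 10000 nM.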

Compound 4, half-maximal inhibitory concentration: > 10000 nM
Compound 4: no number, only a limit; the forecaster's own chance of this, stated with the estimate: 25%; middle value at least 4.0-fold (0.60 log units) away from the limit.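

A single hydroxy, ortho to a methoxy group on the ring of compound 2, is enough to give an at least 10-fold higher number from compound 2 to compound 4 (1.00 log units; beyond the scatter) in this assay. The earlier step, an at least 10-fold lower number from compound 1 to compound 2 (1.00 log units; beyond the scatter), exchanged the whole substitution of that ring, so it could not tie the change to one group; this step differs in one place only and shows that this carbon does not tolerate the hydroxy in this assay. Compound 4 gives only a limit of the assay, so the true size of the step remains a lower bound, and only compound 2 gives a plain number: the limit of > 10000 nM in this assay, at which 2 of the 4 values shown sit.

Going by these compounds, whether the rise belongs to the hydroxy itself or would follow any group on this carbon stays open. A fluorine, an amine or a carboxylic acid at the same place on compound 2 would separate these two readings.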